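A few compounds are considered here, and "the series" means these few. Any claim that something is new, unique, unknown or untested is made for them only; others in the source may bear on it.

Compound 1 `Cc1ccc(-c2cn3nc(Cc4ccc(Cl)cc4)sc3n2)cc1` carries 4-methylphenyl on the shared core. In a functional assay on HeLa cells (Homo sapiens) for cytotoxicity, with a stated time of 72 h (on this read-out higher numbers stand for weaker inhibition and lower numbers for stronger inhibition), compound 1 gives > 250000 nM, which is a limit of the assay and not a number. The value of compound 1 sits at the limit of > 250000 nM in this assay, at which 1 of the 3 values shown sits. Compound 2 `Clc1ccc(Cc2nn3cc(-c4ccc(Cl)cc4Cl)nc3s2)cc1` differs from compound 1 by 2,4-dichlorophenyl in place of 4-methylphenyl on an aromatic carbon. In this assay compound 2 gives 109000 nM; the step is an at least 2.2-fold lower number from compound 1 to compound 2 (0.36 log units; beyond the scatter). Compound 3 `Cc1ccc(-c2nc3sc(Cc4ccc(Cl)cc4)nn3c2C=O)cc1` differs from compound 1 by formyl in place of hydrogen on an aromatic carbon. In this assay compound 3 gives 21000 nM, and the step of an at least 11-fold lower number from compound 1 to compound 3 (1.07 log units; beyond the scatter) is the larger of the two steps seen so far. Compound 4 `O=Cc1c(-c2ccc(Cl)cc2Cl)nc2sc(Cc3ccc(Cl)cc3)nn12` is not yet measured; it differs from compound 3 by 2,4-dichlorophenyl in place of 4-methylphenyl on an aromatic carbon. This is the same kind of change as from compound 1 to compound 2, not the same: around the place, the exchanged group in compound 4 is next to the ring atom that bears a formyl group, which is absent in compound 2. The earlier step of that kind was an at least 2.2-fold lower number from compound 1 to compound 2 (0.36 log units; beyond the scatter). For compound 4 a step of a 3.0-fold lower number from compound 3 to compound 4 (0.48 log units; beyond the scatter) is expected, resting on an at least 2.2-fold lower number from compound 1 to compound 2 (0.36 log units; beyond the scatter). Compound 4 is estimated at 7000 nM, between 2500 nM and 20000 nM.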

Compound 4, half-maximal inhibitory concentration: 64000 nM
Beside the measured number, compound 4's estimate is 9.1-fold (0.96 log units) below it; the whole stated range lies below it.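

In this assay, 2,4-dichlorophenyl in place of 4-methylphenyl does not carry over between cores, since on the formyl-bearing core the step is a 3.0-fold higher number from compound 3 to compound 4 (0.48 log units; beyond the scatter), against the direction of the earlier step: the same change on two cores in this assay, an at least 2.2-fold lower number (0.36 log units; beyond the scatter) from compound 1 to compound 2 and a 3.0-fold higher number (0.48 log units; beyond the scatter) from compound 3 to compound 4, at least 6.9-fold (0.84 log units) apart, beyond the scatter of two such steps

Formyl in place of hydrogen does not keep its size either, because with 2,4-dichlorophenyl present the step is a 1.7-fold lower number from compound 2 to compound 4 (0.23 log units; within the scatter): the same change on two cores in this assay, an at least 11-fold lower number (1.07 log units; beyond the scatter) from compound 1 to compound 3 and a 1.7-fold lower number (0.23 log units; within the scatter) from compound 2 to compound 4, at least 6.9-fold (0.84 log units) apart, beyond the scatter of two such steps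

These four compounds show that neither change can be read across as a fixed step in this series, but they do not show why the steps differ or how large the true gap is, as compound 1 stands only at a limit of the assay: the limit of > 250000 nM in this assay, at which 1 of the 4 values shown sits.

Going by these compounds, it remains open whether this dependence on the partner group extends to other groups on the same aromatic carbon, such as a carboxylic acid or an amine in place of formyl. On these data alone, it also remains open how a hydroxymethyl group there would behave with 4-methylphenyl and with 2,4-dichlorophenyl.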